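The compounds below may be only part of what the source reports. "The series", "measured", "known", "first", "only" and "open" are said of these compounds alone.

Measured so far in a functional assay on MDA-MB-231 cells (Homo sapiens) for inhibition, read by sulforhodamine B assay, with a stated time of 48 h; a higher number here means a weaker inhibitor of growth, a lower number a stronger inhibitor of growth:
- compound 1 `COc1ccc2c(c1)NC(=O)CN2c1nc(Nc2cccc(C#N)c2)nc2ccccc12`: 97.1 nM
- compound 2 `COc1ccc2c(c1)NC(=O)CN2c1nc(NC2CC2)nc2ccccc12`: 10.5 nM

Of these two, compound 2 has the lower number, 10.5 nM. Compound 3 `CCCCNc1nc(N2CC(=O)Nc3cc(OC)ccc32)c2ccccc2n1` has not yet been measured. It has butyl in place of cyclopropyl on a nitrogen on an aromatic ring. Going by the values given here, only one measured step bears on this nitrogen: a 9.2-fold lower number from compound 1 to compound 2 (0.97 log units; beyond the scatter), with cyclopropyl replacing 3-cyanophenyl. That step lies beyond the scatter, so the number does respond to a change at this place. However, no measured step compares two groups made of carbon only, as butyl and cyclopropyl are, so the evidence is thin. A smaller change towards a higher number seems likely in this assay, and the expected change is a 2.4-fold higher number from compound 2 to compound 3 (0.38 log units; beyond the scatter). The estimate for compound 3 is 25 nM, with an expected range of 7 nM to 90 nM.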

Compound 3, concentration for 50% growth inhibition in the MDA-MB-231 assay: 7.19 nM
The estimate for compound 3 lay 3.5-fold (0.54 log units) above the measured number, within the range that was stated.
By their numbers in the MDA-MB-231 assay, from the lowest: compounds 3 and 2 (each within the scatter of the next); then compound 1.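

In the MDA-MB-231 assay, butyl and cyclopropyl on this nitrogen cannot be told apart, a 1.5-fold lower number from compound 2 to compound 3 (0.16 log units; within the scatter), so opening the three-membered ring into a chain leaves this number unresolved. Going by these compounds alone, the larger contrast at this place remains the one with the aromatic group, a 14-fold lower number from compound 1 to compound 3 (1.13 log units; beyond the scatter), and it now holds for a ring-free chain as well as for cyclopropyl. The change that left growth inhibition unresolved does separate the two compounds in a physicochemical assay for solubility, read by HPLC, at pH 7.4 (a lower number here means a less soluble compound, a higher number a more soluble compound), where butyl goes with far lower solubility than cyclopropyl: the measured solubility of compound 2, 67.8 ug/mL, and of compound 3, 1.34 ug/mL, a 51-fold lower number (1.70 log units; beyond the scatter)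

In the physicochemical assay compound 2 stands at 67.8 ug/mL and compound 3 at 1.34 ug/mL as measured. On these data alone, whether a shorter chain such as ethyl, or a butyl chain ending in an amine, would keep the number in the MDA-MB-231 assay while giving solubility closer to that of compound 2 stays open. A single pair also cannot separate the loss of the ring from the added carbon in the physicochemical assay.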